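A Second Methoxy Group on the Pendant Ring

The source may report more compounds than this note shows. Statements on the series, on what has been measured and on what is new or still open speak of the compounds shown alone.

Measured so far in a functional assay for inhibition, tested at 40 ug/mL; a lower number here means a weaker effect, a higher number a stronger effect of the compound at the concentration tested:
compound 1, `COc1cccc(-c2cc(-c3cc(C(C)C)c(O)cc3C)[nH]c(=O)c2C#N)c1`, gives 30%
compound 2, `Cc1cc(O)c(C(C)C)cc1-c1cc(-c2cccs2)c(C#N)c(=O)[nH]1`, gives 41%
compound 3, `COc1ccc(-c2cc(-c3cc(C(C)C)c(O)cc3C)[nH]c(=O)c2C#N)cc1`, gives 35%

Among these three numbers compound 3 sits second highest, yet its gaps to both neighbours are within the scatter, so the three compounds cannot be told apart on this assay. Moving the methoxy group, a number 5 percentage points higher from compound 1 to compound 3 (within the scatter), changed nothing beyond the scatter, and swapping the ring itself, a number 6 percentage points lower from compound 2 to compound 3 (within the scatter), also stayed within it. Only a number 11 percentage points higher from compound 1 to compound 2 (beyond the scatter) counts as a real step, and a modest one.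

Compound 4, `COc1ccc(-c2cc(-c3cc(C(C)C)c(O)cc3C)[nH]c(=O)c2C#N)cc1OC`, differs from compound 3 by methoxy in place of hydrogen on an aromatic carbon. Within the data shown here, none of the measured steps adds a group to the 4-methoxyphenyl ring; the closest point of reference is the shift of the methoxy group from compound 1 to compound 3, which stayed within the scatter. On that basis a change within the scatter is expected for the step of a number 2 percentage points higher from compound 3 to compound 4 (within the scatter) in this assay, with no clear direction. Compound 4 is therefore estimated at 37%, in a range from 22% to 52%.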

Compound 4, a percentage reported as inhibition, at one concentration (the size of the read-out at that concentration, not a potency): 44%
Estimate against measurement, compound 4: 7 percentage points below; the measured number falls inside the stated range.
By their numbers in this assay, from the lowest: compounds 1, 3, 2 and 4 (each within the scatter of the next, the first and the last beyond it).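

Compound 4 shows what adding a group to this pendant ring does, and the answer depends on the starting ring: in this assay, the same methoxy in place of hydrogen stays within the scatter on the 4-methoxyphenyl ring (a number 9 percentage points higher from compound 3 to compound 4 (within the scatter)) but goes beyond it, modestly, on the 3-methoxyphenyl ring (a number 14 percentage points higher from compound 1 to compound 4 (beyond the scatter)). The larger 3,4-dimethoxyphenyl ring also cannot be told apart from the smaller thiophen-2-yl ring (a number 3 percentage points higher from compound 2 to compound 4 (within the scatter)), so a second methoxy group is tolerated here without any loss in this read-out. The data at hand offer no independent measurement that would account for these steps.

Going by these compounds, it remains open whether methoxy is special at this place on the ring or whether another group, such as a hydroxyl, an amine or a longer ethoxy chain, would give a similar number. On these data alone, each number also comes from a single tested concentration, so how these compounds compare in potency remains open as well.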